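A few compounds are considered here, and "the series" means these few. Any claim that something is new, unique, unknown or untested is made for them only; others in the source may bear on it.

Measured compounds in a functional assay on MCF7 cells (Homo sapiens) for antiproliferative activity, read by MTT assay, with a stated time of 48 h; a lower number here means a stronger inhibitor, a higher number a weaker inhibitor:
- Compound 1, `Cc1cccc(-n2nncc2CN2C(=O)C3(C(C#N)=C(N)Oc4c3c3nc5ccccc5nc3c3ccccc43)c3ccccc32)c1`: in this assay compound 1 gives > 50000 nM, a limit of the assay rather than a number.
- Compound 2, `N#CC1=C(N)Oc2c(c3nc4ccccc4nc3c3ccccc23)C12C(=O)N(Cc1cnnn1-c1ccccc1Cl)c1ccccc12`: in this assay compound 2 gives > 50000 nM, likewise a limit.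
- Compound 3, `COc1ccccc1-n1nncc1CN1C(=O)C2(C(C#N)=C(N)Oc3c2c2nc4ccccc4nc2c2ccccc32)c2ccccc21`: in this assay compound 3 gives > 50000 nM, likewise a limit.

Within the data shown here, compound 2 therefore stands where the two other measured compounds stand, at the limit of > 50000 nM in this assay, at which 3 of the 3 values shown sit; no compound of the set has a numerical read-out. The steps that touch compound 2 are a step that the two limits leave unreadable from compound 1 to compound 2 (2-chlorophenyl in place of 3-methylphenyl on an aromatic nitrogen) and a step that the two limits leave unreadable from compound 2 to compound 3 (methoxy in place of chloro on an aromatic carbon); the remaining step, a step that the two limits leave unreadable from compound 1 to compound 3, is equally unreadable. Not one of them yields a size.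

Compound 4, `N#CC1=C(N)Oc2c(c3nc4ccccc4nc3c3ccccc23)C12C(=O)N(Cc1cnnn1-c1cc(Cl)ccc1Cl)c1ccccc12`, differs from compound 2 by chloro in place of hydrogen on an aromatic carbon; cut one bond further out, this reads 2-chlorophenyl to 2,5-dichlorophenyl. Among the measured compounds shown here, no measured step in this assay concerns a second chloro on that aryl ring, and since compound 2 itself is only a limit, no direction can be read for the step. Given that compound 2 sits at > 50000 nM, compound 4 is expected to remain at the limit as well. Compound 4 is thus estimated at 60000 nM, with a range of 20000 nM to 200000 nM, which means an expected step that the limit leaves unreadable from compound 2 to compound 4, i.e. none beyond the scatter.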

Compound 4, half-maximal inhibitory concentration: > 50000 nM
Compound 4 was reported as a limit; the forecaster's own chance of this, stated with the estimate: 85%; the middle value does not contradict the limit.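

Compound 4 adds no readable step, since its comparisons with compound 1, compound 2 and compound 3 all join two limits: the limit of > 50000 nM in this assay, at which 4 of the 4 values shown sit.

The compounds shown leave open whether any change on this aryl ring can give a numerical read-out in this assay.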